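Notes: 4-methoxyphenyl in place of 3,5-difluorophenyl

The source may report more compounds than this note shows. Statements on the series, on what has been measured and on what is new or still open speak of the compounds shown alone.

In an ADME assay on HFF cells (Homo sapiens) for cytotoxicity, read by MTT assay, with a stated time of 72 h (a higher number here means a weaker inhibitor, a lower number a stronger inhibitor), compound 1 (`O=C1O/C(=C\Cn2cc(-c3cc(F)cc(F)c3)nn2)C(OCc2ccccc2)=C1OCc1ccccc1`) gives > 100000 nM, and this is a limit of the assay, not a number. Going by the values given here, the only numerical reading so far comes from compound 2 (`O=C1O[C@H]([C@@H](O)Cn2cc(-c3cccc(O)c3)nn2)C(OCc2ccccc2)=C1OCc1ccccc1`), which gives 39000 nM in this assay. Among the compounds with values here, no measured step between compounds that differ in one place is available to scale from.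

Compound 3 (`COc1ccc(-c2cn(C/C=C3\OC(=O)C(OCc4ccccc4)=C3OCc3ccccc3)nn2)cc1`) carries 4-methoxyphenyl in place of 3,5-difluorophenyl on an aromatic carbon of the five-membered aromatic ring with 3 nitrogen, on the otherwise shared core: 4-methoxyphenyl in place of 3,5-difluorophenyl on an aromatic carbon.

The change expected in this assay is none beyond the scatter, with the reading staying in the region of the limit set by compound 1. The estimated step is an at least 1.2-fold lower number from compound 1 to compound 3 (0.09 log units; that floor lies within the scatter). For compound 3 the expected value is 80000 nM, with an estimated range from 35000 nM to 150000 nM.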

Compound 3, half-maximal inhibitory concentration: > 100000 nM
Compound 3 was reported as a limit; the forecaster's own chance of this, stated with the estimate: 55%; at least 1.2-fold (0.09 log units) between middle value and limit.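

In this assay compound 3 gives > 100000 nM, a limit of the assay and not a number. Compound 1 gives > 100000 nM, also a limit, and no step can be read between compound 1 and compound 3. The compounds shown leave open whether 4-methoxyphenyl and 3,5-difluorophenyl differ at all in this assay.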